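From Furan-3-yl to Pyridin-4-yl on a Shared Core

The source may hold more compounds than are shown below. What is called first, only, known or untested is meant among the compounds shown, and "the series" means these compounds.

The measured compounds in an assay on CHO cells for displacement of a labelled ligand from adenosine receptor A3 (Homo sapiens), read by scintillation counting, tested at 10 uM; on this read-out higher numbers stand for more inhibition at the one concentration tested (going by the name of the read-out) and lower numbers for less inhibition:
compound 1, `Cc1csc(N)c1C(=O)c1ccc(Cl)cc1`, gives 1%.
compound 2, `CC(C)(C)Cc1csc(N)c1C(=O)c1ccc(Cl)cc1`, gives 5%.
compound 3, `CC(C)(C)Cc1c(-c2ccoc2)sc(N)c1C(=O)c1ccc(Cl)cc1`, gives 1%.

Compound 3 stands level with compound 1 at the digits printed, and together the two are the lowest of the three numbers. Its nearest neighbour is compound 1, with no change at the digits printed; its furthest is compound 2, and that distance is small, since the step of a number 4 percentage points lower from compound 2 to compound 3 (within the scatter) lies within the scatter. The step of a number 4 percentage points higher from compound 1 to compound 2 (within the scatter) also lies within the scatter, so nothing in this series has moved the read-out beyond its noise.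

Compound 4, `CC(C)(C)Cc1c(-c2ccncc2)sc(N)c1C(=O)c1ccc(Cl)cc1`, has not yet been measured. It differs from compound 3 as follows: pyridin-4-yl in place of furan-3-yl on an aromatic carbon.

Among the measured compounds shown here, only one measured step touches the same aromatic carbon, the introduction of furan-3-yl from compound 2 to compound 3, and it was within the scatter. For the measured compounds named here, no measured step exchanges furan-3-yl for pyridin-4-yl, so that exchange is untested here. Given that compound 3 gave 1% and that every step in this series stayed within the scatter, compound 4 is expected to show no change beyond the scatter, an estimated step of a number 2 percentage points higher from compound 3 to compound 4 (within the scatter). Compound 4 is therefore estimated at 3%, with a range from -6% to 14%.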

Compound 4, a percentage reported as inhibition, at one concentration (the size of the read-out at that concentration, not a potency): 6%
For compound 4 the middle estimate is 3 percentage points below the measured one; low and high end bracket the measured number.
By their numbers in this assay, from the lowest: compounds 1, 3, 2 and 4 (each within the scatter of the next).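

In this assay the exchange on the aromatic carbon next to the ring sulfur replaces a five-membered aromatic ring with a six-membered one, each with 1 hetero atom, and the step of a number 5 percentage points higher from compound 3 to compound 4 (within the scatter) shows that this change of ring size and hetero atom does not carry the read-out beyond the scatter. Measured against the hydrogen of compound 2, the step of a number 1 percentage points higher from compound 2 to compound 4 (within the scatter) places pyridin-4-yl with furan-3-yl, as neither ring at this carbon separates from the unsubstituted compound in this assay at the one concentration tested. There is no evidence here that bears on these numbers, and nothing can be said about what lies behind them.

As far as these compounds go, whether an amine such as morpholine or a carboxylic acid on this same carbon would give a number beyond the scatter remains open, and so does whether pyridin-4-yl would read the same on the core of compound 1, with methyl where compound 4 has its neopentyl group. All four numbers lie so close together that the series does not yet show which part of the shared core, if any, can move this read-out.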